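The compounds below may be only part of what the source reports. "The series", "measured", "known", "first", "only" and "open" are said of these compounds alone.

Of the compounds shown here, three built on a shared core have been tested in a functional assay on SW480 cells (Homo sapiens) for cytotoxicity, read by sulforhodamine B assay, with a stated time of 48 h; on this read-out higher numbers stand for weaker inhibition and lower numbers for stronger inhibition. Compound 1 `COc1cccc(/C=C/C(=O)c2cccc(-c3cccc(F)c3)c2)c1OC` gives 13500 nM, compound 2 `COc1ccccc1/C=C/C(=O)c1cccc(-c2cccc(F)c2)c1` gives 16600 nM, and compound 3 `COc1ccc(/C=C/C(=O)c2cccc(-c3cccc(F)c3)c2)cc1` gives 4510 nM, the lowest of the three numbers, with both other compounds beyond the scatter of it. Compound 2 and compound 3 have the same atoms joined differently: 4-methoxyphenyl in place of 2-methoxyphenyl on a double-bonded chain carbon bound to a double-bonded chain carbon. This rearrangement produced a 3.7-fold lower number from compound 2 to compound 3 (0.57 log units; beyond the scatter). Compound 1 and compound 2 differ by methoxy in place of hydrogen on an aromatic carbon, a change that gave a 1.2-fold lower number from compound 2 to compound 1 (0.09 log units; within the scatter).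

Compound 4 `COc1ccc(/C=C/C(=O)c2cccc(-c3cccc(F)c3)c2)cc1OC` has not yet been measured. It arises from compound 3 by methoxy in place of hydrogen on an aromatic carbon. This is the same change as between compound 2 and compound 1, the surroundings of the place being described in identical words, so it appears in both pairs. The earlier step was small because a 1.2-fold lower number from compound 2 to compound 1 (0.09 log units; within the scatter) sits within the scatter, and a similar outcome is expected here. The expected step for compound 4 is a 1.1-fold lower number from compound 3 to compound 4 (0.05 log units; within the scatter). In this assay compound 4 is estimated at 4000 nM, probably between 2000 nM and 8000 nM.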

Compound 4, half-maximal inhibitory concentration: 2970 nM
The estimate for compound 4 lay 1.3-fold (0.13 log units) above the measured number; measured number inside the range.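

Methoxy in place of hydrogen on an aromatic carbon, ortho to a methoxy group, gave a 1.5-fold lower number from compound 3 to compound 4 (0.18 log units; within the scatter) in this assay, so this step is too small to separate from ordinary measurement variation. Set beside the earlier step, it shows no sign that the core changes the outcome: the same change on two cores in this assay, a 1.2-fold lower number (0.09 log units; within the scatter) from compound 2 to compound 1 and a 1.5-fold lower number (0.18 log units; within the scatter) from compound 3 to compound 4, 1.2-fold (0.09 log units) apart, within the scatter of two such steps. The change therefore carried across these two cores with a similarly small result, but this does not show that the added methoxy group truly shifts the number in either case, and two pairs cannot establish how it would behave on any other core in the series.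

The compounds shown leave open whether a different group at this place, such as a hydroxyl, an amine or a carboxylic acid, would give a step beyond the scatter. They also leave open whether a longer chain, such as ethoxy in place of methoxy, would do so.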